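This account rests on a few compounds, and the source may have more. Where it says the series, first, only, none or still open, it means among the compounds named here.

Compound 3 `COc1cc2c(cc1OC)C(CC(=O)NC(C)(C)C)CC2` carries a (tert-butyl)amino group on a carbonyl carbon of the shared core. In a functional assay on the whole organism (strain Wistar) for inhibition, with Rattus norvegicus as the target, read by paw edema, with stated times of 60 min and 1 h, at a dose of 100 mg/kg by the oral route (on this read-out higher numbers stand for more inhibition at the one dose given (going by the name of the read-out) and lower numbers for less inhibition), compound 3 gives 31.3%. Compound 2 `CCCCNC(=O)CC1CCc2cc(OC)c(OC)cc21` gives 31.3%, and compound 1 `COc1cc2c(cc1OC)C(CC(=O)N(C)C)CC2` gives 25%. The steps of a number 6.3 percentage points higher from compound 1 to compound 3 (within the scatter) and no change at the digits printed from compound 2 to compound 3 (within the scatter) show that all three numbers sit within the scatter of one another. Compound 4 `CCCCCCNC(=O)CC1CCc2cc(OC)c(OC)cc21` differs from compound 3 by hexyl in place of tert-butyl on an amide-type nitrogen. Among the measured compounds shown here, the one measured step that bears on this is the exchange of one chain for another on the same amide-type nitrogen, no change at the digits printed from compound 2 to compound 3 (within the scatter), which left the number unchanged. A step of the same kind is expected here, a number 0.3 percentage points lower from compound 3 to compound 4 (within the scatter), nothing beyond the scatter. Compound 4 is therefore expected to give 31%, between 20% and 42%.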

Compound 4, a percentage reported as inhibition, in the whole organism at one dose (the size of the read-out at that dose, not a potency): 47.6%
For compound 4 the middle estimate is 16.6 percentage points below the measured one; measured number outside the range, above it.
By their numbers in this assay, from the lowest: compounds 1, 2 and 3 (each within the scatter of the next); then compound 4.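

This position on the amide-type nitrogen can respond to the chain it carries: in this assay, hexyl in place of tert-butyl gives a number 16.3 percentage points higher from compound 3 to compound 4 (beyond the scatter), although butyl and tert-butyl gave numbers within the scatter of each other. Extending the straight chain from butyl to hexyl gives a number 16.3 percentage points higher from compound 2 to compound 4 (beyond the scatter), so chain length counts here, not only the presence of a chain. Hexylamino in place of dimethylamino gives a number 22.6 percentage points higher from compound 1 to compound 4 (beyond the scatter), the widest step in the set. Nothing measured here explains why the hexyl chain gives the higher number. From the compounds shown here alone, whether a longer chain such as octyl would go further, or a hexyl chain ending in an amine or a carboxylic acid would hold the number, stays open.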